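Chain extension on the carbamate nitrogen: compound 3

The compounds below may be only part of what the source reports. "The series", "measured", "known", "first", "only" and "open" are said of these compounds alone.

Measured compounds:
compound 1, `CCCCCCCNC(=O)Oc1ccc(Cl)cc1C(=O)Nc1cccc(Cl)c1`, 5.94
compound 2, `CCCCCCCCCCNC(=O)Oc1ccc(Cl)cc1C(=O)Nc1cccc(Cl)c1`, 7.19

For the measured compounds named here, in a physicochemical assay for lipophilicity (a higher number here means a more lipophilic compound, a lower number a more polar compound), compound 1 gives 5.94, the lower of the two numbers so far. Compound 2, `CCCCCCCCCCNC(=O)Oc1ccc(Cl)cc1C(=O)Nc1cccc(Cl)c1`, gives 7.19 in this assay. Going by the values given here, the only measured step, a number 1.25 log units higher from compound 1 to compound 2 (beyond the scatter), is a propyl in place of hydrogen on a saturated chain carbon, seven bonds along the chain from an amide-type nitrogen.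

Compound 3, `CCCCCCCCCCCNC(=O)Oc1ccc(Cl)cc1C(=O)Nc1cccc(Cl)c1`, is not yet measured. It differs from compound 1 by butyl in place of hydrogen on a saturated chain carbon, seven bonds along the chain from an amide-type nitrogen. Among the compounds with values here, this is the same kind of change as the one from compound 1 to compound 2, carried one carbon further. Within the data shown here, the step from compound 1 to compound 2 is the one measurement that bears on it, and it was large and upward. A step of similar or slightly larger size in this assay is therefore expected for compound 3, which is estimated as a number 1.66 log units higher from compound 1 to compound 3 (beyond the scatter).

For compound 3 the expected value in this assay is 7.6, within 7.2 to 8.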

Compound 3, partition coefficient: 7.61
For compound 3 the middle estimate is 0.01 log units below the measured one, and the stated range covers the measured number.
By their numbers in this assay, from the lowest: compound 1; then compound 2; then compound 3.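

In this assay, butyl in place of hydrogen on a saturated chain carbon, seven bonds along the chain from an amide-type nitrogen, gives a number 1.67 log units higher from compound 1 to compound 3 (beyond the scatter) and so carries the rise seen for the propyl change one step further along the same chain. The new point also shows that a single methyl in place of hydrogen on a saturated chain carbon still registers: it gives a number 0.42 log units higher from compound 2 to compound 3 (beyond the scatter), so the number has not levelled off at the chain of compound 2, and across these three compounds it rises with chain length, with none going against that order. Nothing in the data on hand accounts for the size of these steps.

From the compounds shown here alone, whether a longer chain than that of compound 3 continues the rise or flattens it remains open. Also open, going by these compounds, is how far a terminal amine, a terminal carboxylic acid or a branched chain at this place would pull the number away from this straight-chain trend.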